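Hydroxyphenyl position on the shared core, compound 3 to compound 4

The compounds below may be only part of what the source reports. "The series", "measured", "known", "first", "only" and "open" are said of these compounds alone.

Three analogues of the shared core have been run in an assay on isolated protein for inhibition of DNA topoisomerase 1 (Homo sapiens), with a stated time of 30 min, tested at 20 uM; on this read-out higher numbers stand for a stronger effect at the one concentration tested and lower numbers for a weaker effect. Compound 1 `Oc1ccc(-c2cc(-c3cccs3)cc(-c3ccc(O)cc3)n2)cc1` gives 0.9% in this assay. Compound 2 `Oc1ccc(-c2cc(-c3ccco3)cc(-c3ccccc3O)n2)cc1` gives 0% in this assay. Compound 3 `Oc1ccc(-c2cc(-c3ccco3)cc(-c3cccc(O)c3)n2)cc1` gives 1.5% in this assay, the largest of the three numbers, although it lies within the scatter of compound 1 and of compound 2 alike. Within the data shown here, the only single-point step among the measured set, a number 1.5 percentage points higher from compound 2 to compound 3 (within the scatter), was within the scatter. Compound 4 `Oc1ccc(-c2cc(-c3ccco3)cc(-c3ccc(O)cc3)n2)cc1` is not yet measured. The change from compound 3 is 4-hydroxyphenyl in place of 3-hydroxyphenyl on an aromatic carbon. Among the measured compounds shown here, only the step from compound 2 to compound 3 bears on this move of a hydroxyphenyl, and it gave nothing beyond the scatter; all three measured values sit near the bottom of the read-out, so no step beyond the scatter is expected here either. Compound 4 is therefore expected to give 1% in this assay, with a range of 0% to 8%. This estimate means an expected step of a number 0.5 percentage points lower from compound 3 to compound 4 (within the scatter).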

Compound 4, a percentage reported as inhibition, at one concentration (the size of the read-out at that concentration, not a potency): 0%
Estimate against measurement, compound 4: 1 percentage points above; low and high end bracket the measured number.
By their numbers in this assay, from the lowest: compounds 2, 4, 1 and 3 (each within the scatter of the next).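

In this assay, the 2-hydroxyphenyl, 3-hydroxyphenyl and 4-hydroxyphenyl groups at this place, next to the ring nitrogen, can now be compared, and the move gives a number 1.5 percentage points lower from compound 3 to compound 4 (within the scatter) and no change at the digits printed from compound 2 to compound 4 (within the scatter), so the position of the hydroxyl on this ring separates none of them here. A second place also comes into view: furan-2-yl in place of thiophen-2-yl gives a number 0.9 percentage points lower from compound 1 to compound 4 (within the scatter), so this exchange likewise shows nothing beyond the scatter. No supporting data bear on these results.

Still open, going by these compounds, is whether any change at either place can move the number beyond the scatter, since all the compounds shown sit close together near the bottom of the read-out. An aminophenyl or a carboxyphenyl group at the place next to the ring nitrogen would test this.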